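A few compounds are considered here, and "the series" means these few. Any claim that something is new, unique, unknown or untested is made for them only; others in the source may bear on it.

Measured in a functional assay on the whole organism with Mus musculus as the target, in the rotarod test (on this read-out lower numbers stand for an effect already at smaller amounts and higher numbers for an effect only at larger amounts of compound), so far
Compound 1 (`CN(C(=O)CNC(=O)CN)c1ccc([N+](=O)[O-])cc1C(=O)c1ccccc1Cl`) gives 10 mg/kg
Compound 2 (`CC(=O)NCC(=O)N(C)c1ccc(Cl)cc1C(=O)c1ccccc1Cl`) gives 58 mg/kg
Compound 3 (`NC(C(=O)NCC(=O)Nc1ccc(Cl)cc1C(=O)c1ccccc1)c1ccccc1`) gives > 100 mg/kg (a limit)

Compound 2 reads 58 mg/kg and so holds the higher of the two true numbers here. Compound 1 reads 10 mg/kg and lies lower, a gap beyond the usual scatter. Compound 3 gives > 100 mg/kg as its entry, which is a limit of the assay and not a number.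

The next compound, compound 4 (`CCC(=O)NCC(=O)N(C)c1ccc(Cl)cc1C(=O)c1ccccc1Cl`), differs from compound 2 in one place only. The change is methyl in place of hydrogen on a saturated chain carbon bound to a carbonyl carbon and reads, in words, methyl in place of hydrogen on a saturated chain carbon bound to a carbonyl carbon, turning acetamido into propanoylamino. Among the compounds with values here, no measured pair differs in one place alone, so the data give no direct size for such a step. In this assay no step beyond the scatter is expected, in either direction. The expected size is a 1.2-fold lower number from compound 2 to compound 4 (0.06 log units; within the scatter) and it stays within the scatter. Compound 4 is estimated at 50 mg/kg with an expected range from 20 mg/kg to 100 mg/kg as the likely span.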

Compound 4, dose for half-maximal effect: 36 mg/kg
Beside the measured number, compound 4's estimate is 1.4-fold (0.14 log units) above it; the range from low to high includes it.
By their numbers in this assay, from the lowest: compound 1; then compounds 4 and 2 (each within the scatter of the next). At a limit, above all of these: compound 3.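

Within the data shown here, compound 2 and compound 4 form the first pair that differs in one place, so the size of a change on this saturated chain carbon bound to a carbonyl carbon can now be read. In this assay, turning acetamido into propanoylamino gives a 1.6-fold lower number from compound 2 to compound 4 (0.21 log units; within the scatter), so the added methyl leaves the read-out where it was, and this place accepts propanoylamino without a step beyond the scatter. Nothing measured here speaks to a cause for this result.

Going by these compounds, whether a longer chain, such as butanoylamino, or a carboxylic acid at this place would also leave the read-out unchanged remains open. The compounds shown also leave open what sets compound 1 apart from compound 2, since the two differ in more than one place.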